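This account rests on a few compounds, and the source may have more. Where it says the series, first, only, none or still open, it means among the compounds named here.

Compound 2 `N#Cc1ccc(Nc2nc(Oc3ccnc4ccccc34)nc(N3CCN(Cc4ccccc4)CC3)n2)cc1C(F)(F)F` reaches in a functional assay on DU-145 cells (Homo sapiens) for cytotoxicity, read by sulforhodamine B assay, with a stated time of 48 h (on this read-out higher numbers stand for weaker inhibition of growth and lower numbers for stronger inhibition of growth), only a limit of the assay, > 100000 nM. Compound 1 `N#Cc1ccc(Nc2nc(Oc3ccnc4ccccc34)nc(N3CCN(c4cccc(C(F)(F)F)c4)CC3)n2)cc1C(F)(F)F` gives 38700 nM. Among the measured compounds shown here, the one measured step, an at least 2.5-fold higher number from compound 1 to compound 2 (0.41 log units; beyond the scatter), runs toward weaker growth inhibition when benzyl replaces an aryl group on the ring nitrogen, and the limit of > 100000 nM in this assay, at which 1 of the 2 values shown sits, marks how compound 2 ends at the edge of the assay. Compound 3 `N#Cc1ccc(Nc2nc(Oc3ccnc4ccccc34)nc(N3CCN(c4ccccc4F)CC3)n2)cc1C(F)(F)F` differs from compound 2 by 2-fluorophenyl in place of benzyl on an amine nitrogen in a ring, putting an aryl group back on that nitrogen. Compound 3 is therefore expected to show the reverse of that step, an at least 2.0-fold lower number from compound 2 to compound 3 (0.30 log units; that floor lies within the scatter), landing near compound 1, with an estimate of 50000 nM and a range from 15000 nM to 150000 nM.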

Compound 3, concentration for 50% growth inhibition: > 100000 nM
Compound 3 ended at the assay's limit; the forecaster's own chance of this, stated with the estimate: 35%; middle value at least 2.0-fold (0.30 log units) away from the limit.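

Putting an aryl group back on the ring nitrogen does not by itself bring back growth inhibition in this assay: 2-fluorophenyl in place of 3-(trifluoromethyl)phenyl gives an at least 2.5-fold higher number from compound 1 to compound 3 (0.41 log units; beyond the scatter). Among the three compounds, only compound 1 therefore has a readable number. The step from compound 2 to compound 3 cannot be read, because both sit at a limit rather than at a number: the limit of > 100000 nM in this assay, at which 2 of the 3 values shown sit.

The compounds shown leave open whether the trifluoromethyl group itself or its place on the phenyl ring carries this difference. They also leave open whether a methyl or methoxy group on that phenyl ring would give a readable number.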